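Methyl to 2-Chlorophenyl on a Carbonyl Carbon

The compounds below may be only part of what the source reports. "The series", "measured", "known", "first", "only" and "open" are said of these compounds alone.

Measured compounds:
compound 1 `O=C(Nc1cc(C(F)(F)F)cc(C(F)(F)F)c1)C1CCc2ccccc2N1C(=O)c1ccccc1Cl`: 5250 nM
compound 2 `CC(=O)N1c2ccccc2CCC1C(=O)Nc1cc(C(F)(F)F)cc(C(F)(F)F)c1`: > 70000 nM
compound 3 `CC(=O)N1c2ccccc2CCC1C(=O)Nc1ccccc1C(F)(F)F`: > 80000 nM

All three compounds were tested in a functional assay on MDA-MB-231 cells (Homo sapiens) for cytotoxicity, read by sulforhodamine B assay, with a stated time of 72 h; on this read-out lower numbers stand for stronger inhibition of growth and higher numbers for weaker inhibition of growth. Compound 1 gives a clear number, 5250 nM. For compound 2 the result is only a limit, > 70000 nM, and not a number. For compound 3 the result is likewise only a limit, > 80000 nM.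

Compound 2 and compound 1 share a core and differ in one place: 2-chlorophenyl in place of methyl on a carbonyl carbon. This change brought an at least 13-fold lower number from compound 2 to compound 1 (1.12 log units; beyond the scatter). Compound 2 sits at the limit of > 70000 nM in this assay, at which 1 of the 3 values shown sits, so the true size of that step is not known beyond the stated lower bound.

Compound 3 and compound 2 differ in the part attached to the amide nitrogen; the difference between the two cores is not broken down here. Compound 3 sits at the limit of > 80000 nM in this assay, at which 1 of the 3 values shown sits.

The unmeasured compound 4 `O=C(Nc1ccccc1C(F)(F)F)C1CCc2ccccc2N1C(=O)c1ccccc1Cl` arises from compound 3 by the same change: 2-chlorophenyl in place of methyl on a carbonyl carbon. Both changes sit on a carbonyl carbon whose other neighbours are an amide-type nitrogen in a ring, so the change is the same in both pairs.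

Since compound 3 starts from a limit, its step cannot be sized exactly; the expected step is an at least 5.3-fold lower number from compound 3 to compound 4 (0.72 log units; beyond the scatter), resting on the step from compound 2 to compound 1 of an at least 13-fold lower number from compound 2 to compound 1 (1.12 log units; beyond the scatter). Compound 4 is therefore estimated at 15000 nM, with a range from 4000 nM to 80000 nM.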

Compound 4, concentration for 50% growth inhibition: 2530 nM
For compound 4 the middle estimate is 5.9-fold (0.77 log units) above the measured one; the whole stated range lies above it.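

In this assay, the same swap of methyl for 2-chlorophenyl on a carbonyl carbon, whose other neighbour is an amide-type nitrogen in a ring, again gave a large move towards stronger inhibition of growth on the second core, with an at least 31-fold lower number from compound 3 to compound 4 (1.49 log units; beyond the scatter). The starting result for compound 3, > 80000 nM, is a limit and not a number. The change thus pointed the same way in both pairs of compounds, which suggests that its direction carried over between these two cores, but two pairs make no general rule and the sizes of the two steps cannot be compared: the same change on two cores in this assay, an at least 13-fold lower number (1.12 log units; beyond the scatter) from compound 2 to compound 1 and an at least 31-fold lower number (1.49 log units; beyond the scatter) from compound 3 to compound 4; the limit leaves it open whether they differ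

The compounds shown leave open which part of the 2-chlorophenyl group matters, since nothing here separates the chlorine from the aromatic ring, as a plain phenyl group on the same carbonyl carbon would do. They also leave open how other groups in that place would behave, such as a longer chain like propyl, a saturated ring like cyclohexyl, or a phenyl ring carrying an amine or a carboxylic acid.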